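Cytotoxicity series: N-aryl variation on the shared core

The source may hold more compounds than are shown below. What is called first, only, known or untested is meant among the compounds shown, and "the series" means these compounds.

Measured so far:
compound 1 `N=C1S/C(=C\c2ccc(OCc3ccccc3)cc2)C(=O)N1c1ccc(Br)cc1` — 7.83%
compound 2 `N=C1S/C(=C\c2ccc(OCc3ccccc3)cc2)C(=O)N1c1cccc([N+](=O)[O-])c1` — 52.9%

In an ADME assay on RAW264.7 cells (Mus musculus) for cytotoxicity, read by MTT assay, with a stated time of 48 h, tested at 50 uM (a higher number here means more inhibition at the concentration tested (going by the name of the read-out), a lower number less inhibition), compound 2 stands highest of the two numbers; the nearest is compound 1, with the step of a number 45.1 percentage points higher from compound 1 to compound 2 (beyond the scatter). Compound 3 `N=C1S/C(=C\c2ccc(OCc3ccccc3)cc2)C(=O)N1c1ccc(Cl)cc1Cl` is to be measured; the change is 2,4-dichlorophenyl in place of 3-nitrophenyl on an amide-type nitrogen in a ring. Within the data shown here, the one step available bears directly on it: it ran from a halogen-bearing aryl to the nitro-bearing aryl and was large. Compound 3 returns to a halogen-bearing aryl, so a drop beyond the scatter is expected, though not necessarily back to compound 1. The estimate for compound 3 is 22% (range 5% to 42%), an expected step of a number 30.9 percentage points lower from compound 2 to compound 3 (beyond the scatter).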

Compound 3, a percentage reported as inhibition, at one concentration (the size of the read-out at that concentration, not a potency): 13.8%
Estimate against measurement, compound 3: 8.2 percentage points above; the range from low to high includes it.
By their numbers in this assay, from the lowest: compounds 1 and 3 (each within the scatter of the next); then compound 2.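

In this assay, replacing 3-nitrophenyl with 2,4-dichlorophenyl on the amide-type nitrogen gives a number 39.1 percentage points lower from compound 2 to compound 3 (beyond the scatter), so the high number does not carry over to this halogen-bearing aryl. Replacing 4-bromophenyl with 2,4-dichlorophenyl gives a number 6 percentage points higher from compound 1 to compound 3 (within the scatter), so among these three compounds only 3-nitrophenyl stands apart. No available data explain this difference at the position.

The compounds shown leave open whether the high number depends on the nitro group alone or on 3-nitrophenyl as a whole. From the compounds shown here alone, how an aryl carrying an amine or a carboxylic acid would read here also remains open.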